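Antiproliferative series: five-membered aromatic replaces pyridin-2-yl

This account rests on a few compounds, and the source may have more. Where it says the series, first, only, none or still open, it means among the compounds named here.

Measured compounds:
- compound 1 `O=C(Nc1ccc(-c2cscn2)cc1)C1CCN(Cc2ccc(F)c(F)c2)C1`: 10000 nM
- compound 2 `O=C(Nc1ccc(-c2cscn2)cc1)C1CCCN(Cc2ccc3cn[nH]c3c2)C1`: > 20000 nM
- compound 3 `O=C(Nc1ccc(-c2ccccn2)cc1)C1CCCN(Cc2ccc(F)c(F)c2)C1`: 9000 nM

In a functional assay on A-375 cells (Homo sapiens) for antiproliferative activity (on this read-out higher numbers stand for weaker inhibition and lower numbers for stronger inhibition), compound 3 gives 9000 nM. Its nearest neighbour is compound 1, whose number in this assay is 10000 nM, and the two sit within the usual scatter of each other, so no order between them can be read. Compound 2 gives > 20000 nM in this assay, which is a limit of the assay and not a number.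

Compound 4 `O=C(Nc1ccc(-c2ccc[nH]2)cc1)C1CCCN(Cc2ccc(F)c(F)c2)C1` is not yet measured. It differs from compound 3 in one place: 1H-pyrrol-2-yl in place of pyridin-2-yl on an aromatic carbon. Going by the values given here, no measured pair isolates such a change, so there is nothing here to say what this swap does. Among the compounds with values here, the three compounds so far sit in a narrow band, with weak inhibition throughout.

Given that compound 3 gives 9000 nM, the step expected a 1.1-fold higher number from compound 3 to compound 4 (0.05 log units; within the scatter) is judged to be none beyond the scatter. Compound 4 is therefore estimated at 10000 nM in this assay, with a range from 4000 nM to 25000 nM.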

Compound 4, half-maximal inhibitory concentration: 360 nM
Beside the measured number, compound 4's estimate is 28-fold (1.44 log units) above it, outside the stated range (below it).
By their numbers in this assay, from the lowest: compound 4; then compounds 3 and 1 (each within the scatter of the next). At a limit, above all of these: compound 2.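

In this assay, the place on an aromatic carbon, para to a large group, proves sensitive to the group it carries: 1H-pyrrol-2-yl in place of pyridin-2-yl gives a 25-fold lower number from compound 3 to compound 4 (1.40 log units; beyond the scatter). Going by these compounds alone, the earlier compounds held no pair that isolated a change at this place, so this is the first measured sign that it matters for the series. The swap alters ring size and the hydrogen-bond donor and acceptor counts together, so this single step does not separate them.

As far as these compounds go, whether the ring size or the pyrrole donor hydrogen carries the step stays open, and a furan-2-yl or 1-methyl-1H-pyrrol-2-yl group at this place would tell the two apart. No measurement shown here bears on the cause of the step.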